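The compounds below may be only part of what the source reports. "The series", "measured", "known", "first", "only" and "open" are said of these compounds alone.

Compound 1, `COc1ccc2c(=O)c(/C=C/C(=O)Nc3cccc(C)c3)coc2c1`: > 100000 nM
Compound 2, `COc1ccc2c(=O)c(/C=C/C(=O)Nc3ccccc3Cl)coc2c1`: 23000 nM
Compound 3, `COc1ccc2c(=O)c(/C=C/C(=O)Nc3ccccc3OC)coc2c1`: 17600 nM

All three were tested in a functional assay (QGY7701 cells, Homo sapiens) for inhibition, read by MTT assay, with a stated time of 48 h; on this read-out lower numbers stand for stronger inhibition and higher numbers for weaker inhibition. For compound 1 the value > 100000 nM is a limit of this assay and not a measured number (the limit of > 100000 nM in this assay, at which 1 of the 3 values shown sits), so compound 1 stands only as the weakest-read member of this small set, without a firm figure. Compound 2 gives 23000 nM in this assay, and compound 3 gives 17600 nM; the step of a 1.3-fold lower number from compound 2 to compound 3 (0.12 log units; within the scatter) lies within the scatter, so these two are not told apart.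

The unmeasured compound 4, `COc1ccc2c(=O)c(/C=C/C(=O)Nc3ccccc3C)coc2c1`, differs from compound 1 by 2-methylphenyl in place of 3-methylphenyl on an amide-type nitrogen. Going by the values given here, two measured steps bear on this change, since each also replaces the 3-methylphenyl group on the amide-type nitrogen with a group carrying its substituent in the 2-position: an at least 4.3-fold lower number from compound 1 to compound 2 (0.63 log units; beyond the scatter) and an at least 5.6-fold lower number from compound 1 to compound 3 (0.75 log units; beyond the scatter). Both are at least modest and point the same way, toward a lower number. The expectation for compound 4 in this assay is therefore a step of similar size in the same direction, an at least 3.3-fold lower number from compound 1 to compound 4 (0.52 log units; beyond the scatter). Compound 4 is thus estimated at 30000 nM, with a range from 9000 nM to 120000 nM.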

Compound 4, half-maximal inhibitory concentration: 22500 nM
Compound 4: middle estimate off by 1.3-fold (0.12 log units), on the high side, and the stated range covers the measured number.
By their numbers in this assay, from the lowest: compounds 3, 4 and 2 (each within the scatter of the next). At a limit, above all of these: compound 1.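

Going by these compounds alone, compound 4 has the same atoms as compound 1, so the swap of 3-methylphenyl for 2-methylphenyl on the amide-type nitrogen isolates the change in where the methyl sits, and in this assay it gives an at least 4.4-fold lower number from compound 1 to compound 4 (0.64 log units; beyond the scatter); the earlier steps from compound 1 changed the substituent as well. With the group in this form, the substituent itself makes no readable difference, with a 1.3-fold higher number from compound 3 to compound 4 (0.11 log units; within the scatter) and a 1.0-fold lower number from compound 2 to compound 4 (0.01 log units; within the scatter), so methyl, methoxy and chloro are not told apart in compounds 2, 3 and 4. The step from compound 1 has no firm size, since the reading for compound 1 is a limit and not a number: the limit of > 100000 nM in this assay, at which 1 of the 4 values shown sits.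

The compounds shown leave open whether 2-hydroxyphenyl, 2-aminophenyl or 2-carboxyphenyl on the amide-type nitrogen would read like compounds 2, 3 and 4. Within the data shown here, they also leave open whether 3-chlorophenyl or 3-methoxyphenyl would read like compound 1, as 3-methylphenyl is the only such group here, and where 4-methylphenyl would fall.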